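The compounds below may be only part of what the source reports. "The series", "measured", "known", "first", "only" and "open" are said of these compounds alone.

Three compounds share one core and differ only in the group on an aromatic carbon of the five-membered ring. Compound 1 `Cc1nn(-c2nc(-c3ccc(Cl)c(Cl)c3)c(SC(C)C)s2)c(C(=O)O)c1-c1cccc(F)c1` carries a 3-fluorophenyl group there, and in a functional assay on BJAB cells (Homo sapiens) for antiproliferative activity, with a stated time of 4 days (a higher number here means that more compound is needed for the effect, a lower number that less compound is needed), compound 1 gives 900 nM. Compound 2 `Cc1nn(-c2nc(-c3ccc(Cl)c(Cl)c3)c(SC(C)C)s2)c(C(=O)O)c1-c1ccccc1[N+](=O)[O-]` carries a 2-nitrophenyl group, and in this assay compound 2 gives 4700 nM. Compound 3 `Cc1nn(-c2nc(-c3ccc(Cl)c(Cl)c3)c(SC(C)C)s2)c(C(=O)O)c1-c1cnccn1` carries a pyrazin-2-yl group, and in this assay compound 3 gives 14000 nM. Compound 3 thus stands highest of the three: the change to it gives a 16-fold higher number from compound 1 to compound 3 (1.19 log units; beyond the scatter) and a 3.0-fold higher number from compound 2 to compound 3 (0.47 log units; beyond the scatter), both beyond the scatter.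

Compound 4 `CCOc1ncccc1-c1c(C)nn(-c2nc(-c3ccc(Cl)c(Cl)c3)c(SC(C)C)s2)c1C(=O)O` has not yet been measured. It differs from compound 3 in one place: 2-ethoxypyridin-3-yl in place of pyrazin-2-yl on an aromatic carbon. The two steps that lead into compound 3 both bear on this change, since both replaced a six-membered ring with one or no hetero atom by pyrazin-2-yl and both raised the number, one modestly and one by a large amount. Reversing that direction, with a six-membered ring of one hetero atom entering, is therefore expected to lower the number beyond the scatter, though how far remains uncertain because only two such steps exist. Compound 4 is expected to give 1800 nM in this assay, within a range from 500 nM to 6000 nM. The expected step is a 7.8-fold lower number from compound 3 to compound 4 (0.89 log units; beyond the scatter).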

Compound 4, half-maximal effective concentration: 11000 nM
For compound 4 the middle estimate is 6.1-fold (0.79 log units) below the measured one; the whole stated range lies below it.
By their numbers in this assay, from the lowest: compound 1; then compound 2; then compounds 4 and 3 (each within the scatter of the next).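

In this assay, putting 2-ethoxypyridin-3-yl in place of pyrazin-2-yl leaves the number within the scatter, with a 1.3-fold lower number from compound 3 to compound 4 (0.10 log units; within the scatter) as the step, so a ring with one hetero atom and more heavy atoms does not by itself separate compound 4 from compound 3. The steps of a 2.3-fold higher number from compound 2 to compound 4 (0.37 log units; beyond the scatter) and a 12-fold higher number from compound 1 to compound 4 (1.09 log units; beyond the scatter) put compound 4 alongside compound 3 at the high end of the set, and this shows that the count of ring hetero atoms does not order the four compounds: compound 4 has one and compound 3 has two, yet neither can be told apart from the other here. At this position, next to the ring atom that bears a carboxy group, only compound 1 with its 3-fluorophenyl group stands clearly apart from all the others, at 900 nM in this series.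

The compounds shown do not separate the part played by the ethoxy chain from that of the pyridine ring, and a plain pyridin-3-yl or a 3-aminophenyl group at this place would be needed to tell these apart. No measurement at hand explains why these groups give the numbers they do.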